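A few compounds are considered here, and "the series" means these few. Any claim that something is new, unique, unknown or untested is made for them only; others in the source may bear on it.

Measured so far:
- compound 1 `Nc1nc2cc(Cl)c(Cl)cc2n1Cc1ccccc1`: 170000 nM
- compound 2 `Nc1nc2cc(Cl)c(Cl)cc2n1Cc1ccc(Cl)cc1`: 45000 nM

Compound 1 stands highest of the two numbers in a functional assay on KB cells (Homo sapiens) for inhibition; on this read-out higher numbers stand for weaker inhibition and lower numbers for stronger inhibition. Compound 3 `CC(C)(C)c1ccc(Cn2c(N)nc3cc(Cl)c(Cl)cc32)cc1` has not yet been measured. It keeps the core of compound 1 and carries tert-butyl in place of hydrogen on an aromatic carbon, para to a large group: tert-butyl in place of hydrogen on an aromatic carbon. Among the compounds with values here, only one measured step bears on this change, chloro in place of hydrogen on an aromatic carbon, which gave a 3.8-fold lower number from compound 1 to compound 2 (0.58 log units; beyond the scatter). That step is modest, and it involves a different group, so it is only a loose guide. A step of similar or slightly larger size towards a lower number is expected in this assay. The estimated step is a 5.7-fold lower number from compound 1 to compound 3 (0.75 log units; beyond the scatter). Compound 3 is therefore expected at 30000 nM, with an estimated range of 10000 nM to 90000 nM.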

Compound 3, half-maximal inhibitory concentration: 50000 nM
For compound 3 the middle estimate is 1.7-fold (0.22 log units) below the measured one; the measured number falls inside the stated range.
By their numbers in this assay, from the lowest: compounds 2 and 3 (each within the scatter of the next); then compound 1.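

In this assay, a substituent on this aromatic carbon, para to a large group, lowers the number for a second group as well: tert-butyl in place of hydrogen gives a 3.4-fold lower number from compound 1 to compound 3 (0.53 log units; beyond the scatter), so the lowering is not confined to chloro. Tert-butyl in place of chloro gives a 1.1-fold higher number from compound 2 to compound 3 (0.05 log units; within the scatter), so compound 2 and compound 3 cannot be told apart on this read-out, and the two groups are interchangeable at this position as far as these numbers go. Nothing available accounts for this result.

Still open, going by these compounds, is whether an amine, a hydroxyl or a carboxylic acid on this carbon would lower the number in the same way. On these data alone, it is also open whether a longer chain or a phenyl ring here would move the number further than chloro and tert-butyl do.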